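From a Propoxy Ether to a Cyclohexyl Ring

The source may hold more compounds than are shown below. What is called first, only, known or untested is meant among the compounds shown, and "the series" means these compounds.

Of the compounds shown here, three have been measured in an assay on cells for antagonist activity at transient receptor potential cation channel subfamily V member 1 (Homo sapiens), read by FLIPR and calcium flux, with a stated time of 6 min; a higher number here means a weaker inhibitor, a lower number a stronger inhibitor. Compound 1 `CC(C)COc1nc(C(C)(C)C)ccc1CNC(=O)C(C)c1ccc(NS(C)(=O)=O)c(F)c1` gives 0.6 nM, and compound 2 `CC(C)CCOc1nc(C(C)(C)C)ccc1CNC(=O)C(C)c1ccc(NS(C)(=O)=O)c(F)c1` gives 0.8 nM; the step between them is a 1.3-fold higher number from compound 1 to compound 2 (0.12 log units; within the scatter). Compound 3 `CCCOc1cc(C(C)(C)C)ccc1CNC(=O)C(C)c1ccc(NS(C)(=O)=O)c(F)c1` gives 4.4 nM, the highest number of the three, beyond the scatter from both compound 1 and compound 2.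

The new compound 4 `CC(C(=O)NCc1ccc(C(C)(C)C)cc1C1CCCCC1)c1ccc(NS(C)(=O)=O)c(F)c1` differs from compound 3 in one place: cyclohexyl in place of propoxy on an aromatic carbon. Among the compounds with values here, no measured step bears on this change directly. Within the data shown here, the only step on hand, from compound 1 to compound 2, swaps one saturated chain for another and stays within the scatter; it says nothing about losing the oxygen or bringing in a ring. The expectation for compound 4 therefore rests on compound 3 alone, with wide uncertainty in either direction, and the step of a 1.4-fold higher number from compound 3 to compound 4 (0.13 log units; within the scatter) is expected to be modest. Compound 4 is estimated to give 6 nM in this assay, within a range from 1.5 nM to 25 nM.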

Compound 4, inhibition constant: 9.8 nM
Beside the measured number, compound 4's estimate is 1.6-fold (0.21 log units) below it; the measured number falls inside the stated range.
By their numbers in this assay, from the lowest: compounds 1 and 2 (each within the scatter of the next); then compound 3; then compound 4.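

Across a 2.2-fold higher number from compound 3 to compound 4 (0.35 log units; beyond the scatter), the oxygen-linked chain on this aromatic carbon gives way to a ring of carbon only, and the number rises by a modest step. Within the data shown here, compounds 1, 2 and 3 all carry an ether oxygen here, so compound 4 is the first to show that this place tolerates its absence, with activity in this assay still measurable at 9.8 nM. Nothing available explains the shift in either direction.

The step combines the loss of the oxygen with the arrival of the ring, and the compounds shown do not separate the two. Going by these compounds, a cyclohexyloxy group would keep both the ring and the oxygen, a butyl chain would keep a chain without the oxygen, and how either would read at this position remains open.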